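A Methyl Gives Way to an Amide on the Ring

The source may hold more compounds than are shown below. What is called first, only, known or untested is meant among the compounds shown, and "the series" means these compounds.

Three compounds share one core and differ only in the saturated ring attached to an aromatic carbon. Compound 1 `O=C(CCc1ccc(C(F)(F)F)cc1)Nc1ccc2nc(N3CCCCC3)ccc2c1` carries piperidin-1-yl there, and in an assay on isolated protein for displacement of a labelled ligand from melanin-concentrating hormone receptor 1 (Homo sapiens) (a higher number here means a weaker inhibitor, a lower number a stronger inhibitor), compound 1 gives 12 nM. Compound 2 `NC1CCN(c2ccc3cc(NC(=O)CCc4ccc(C(F)(F)F)cc4)ccc3n2)C1` carries 3-aminopyrrolidin-1-yl instead; in this assay compound 2 gives 12 nM, and no change at the digits printed from compound 1 to compound 2 (within the scatter). Compound 3 `CC1CCN(c2ccc3cc(NC(=O)CCc4ccc(C(F)(F)F)cc4)ccc3n2)C1` bears 3-methylpyrrolidin-1-yl, and in this assay compound 3 gives 2 nM, the lowest number of the three: a 6.0-fold lower number from compound 1 to compound 3 (0.78 log units; beyond the scatter), and a 6.0-fold lower number from compound 2 to compound 3 (0.78 log units; beyond the scatter).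

Compound 4 `CC(C)C(=O)NC1CCN(c2ccc3cc(NC(=O)CCc4ccc(C(F)(F)F)cc4)ccc3n2)C1` is the next step from compound 3: (isopropylcarbonyl)amino in place of methyl on a saturated ring carbon. Going by the values given here, two measured steps bear on it. The exchange on that same ring carbon, a 6.0-fold lower number from compound 2 to compound 3 (0.78 log units; beyond the scatter), shows that the group at this position moves the number by a modest amount, and a 6.0-fold lower number from compound 1 to compound 3 (0.78 log units; beyond the scatter) shows the same size of effect from a change of the whole ring. Among the compounds with values here, no measured compound carries a group as large as (isopropylcarbonyl)amino, so the direction is not settled by the data; the amino-bearing compound 2 suggests the number may drift back toward its level. Compound 4 is therefore expected to show a 5.0-fold higher number from compound 3 to compound 4 (0.70 log units; beyond the scatter), with an estimate of 10 nM and a range from 2 nM to 50 nM.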

Compound 4, half-maximal inhibitory concentration: 1 nM
Compound 4: the middle estimate sits 10-fold (1.00 log units) above what was measured, and the stated range ends above it.
By their numbers in this assay, from the lowest: compounds 4 and 3 (each within the scatter of the next); then compounds 1 and 2 (each within the scatter of the next).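

The amino group of compound 2 and its acylated form do not sit at the same level: placing isopropylcarbonyl on that amine nitrogen gives a large step (a 12-fold lower number from compound 2 to compound 4 (1.08 log units; beyond the scatter)) in this assay, so the effect of an amino group at this ring carbon does not carry over to its amide. Methyl and the (isopropylcarbonyl)amino group, with 1 and 6 heavy atoms, leave the number within the scatter (a 2.0-fold lower number from compound 3 to compound 4 (0.30 log units; within the scatter)), so this saturated ring carbon, two ring bonds from the ring nitrogen, accepts a much larger group than compound 3 showed, and the step from the piperidin-1-yl compound is also large (a 12-fold lower number from compound 1 to compound 4 (1.08 log units; beyond the scatter)). Nothing available on these compounds explains why the amide and the free amine differ.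

The compounds shown leave open whether the amide hydrogen or the carbonyl matters, a question that an N-methyl amide, a sulfonamide or a simple ether at the same ring carbon would address. They also leave open how far the acyl group can grow, as with a longer chain or a carboxylic acid at its end, and whether the same amide on a piperidin-1-yl ring would give a similar number.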